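The source may hold more compounds than are shown below. What is called first, only, known or untested is meant among the compounds shown, and "the series" means these compounds.

Within the pair measured in an ADME assay (liver) for pharmacokinetics, with Liver microsome (Rattus norvegicus) as the target, using microsomes (a higher number here means that the compound lasts longer, a lower number that the compound disappears faster), compound 1 `CCOC(=O)/C=C/c1ccc(NC(=O)C2(NC(=O)c3ccc4c(C5CCCC5)c(-c5ncc(Cl)cn5)n(C)c4c3)CCC2)cc1OCC` gives 3.07 h and compound 2 `CCCOC(=O)/C=C/c1ccc(NC(=O)C2(NC(=O)c3ccc4c(C5CCCC5)c(-c5ncc(Cl)cn5)n(C)c4c3)CCC2)cc1OCC` gives 0.35 h, the lower of the two numbers. Within the data shown here, the one step in hand, an 8.8-fold lower number from compound 1 to compound 2 (0.94 log units; beyond the scatter), is the only measured change on the ester side of the shared core, and it ran downward and beyond the scatter. Compound 3 `CCOc1cc(NC(=O)C2(NC(=O)c3ccc4c(C5CCCC5)c(-c5ncc(Cl)cn5)n(C)c4c3)CCC2)ccc1/C=C/C(=O)OCC(C)C` carries the next change on the same chain: methyl in place of hydrogen on a saturated chain carbon bound to two saturated chain carbons. Among the measured compounds shown here, no measured pair shows this branching, so the expectation rests on that single step alone; a further methyl on this chain is expected to leave the number near that of compound 2, or to move it only within the scatter, rather than to bring back the level of compound 1. For compound 3 the estimate in this assay is 0.33 h, with a range of 0.12 h to 0.9 h. The step this implies from compound 2 is expected to be a 1.1-fold lower number from compound 2 to compound 3 (0.03 log units; within the scatter).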

Compound 3, half-life: 1.42 h
Compound 3: middle estimate off by 4.3-fold (0.63 log units), on the low side, outside the stated range (above it).
By their numbers in this assay, from the lowest: compound 2; then compound 3; then compound 1.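

In this assay, the ester chain does not lose half-life steadily as it grows: the propyl to isobutyl change gives a 4.1-fold higher number from compound 2 to compound 3 (0.61 log units; beyond the scatter), and so a methyl on this saturated chain carbon runs opposite to the earlier step of an 8.8-fold lower number from compound 1 to compound 2 (0.94 log units; beyond the scatter). The recovery is only partial, at a 2.2-fold lower number from compound 1 to compound 3 (0.33 log units; beyond the scatter), leaving compound 1 with the highest number of the set. Nothing at hand indicates why the branched and straight chains differ.

Still open, on these data alone, is whether the rise belongs to branching at this carbon generally or to the isobutyl group alone, and how a cyclopropylmethyl group, a longer chain or a carboxylic acid in place of the ester would read. With so few esters shown, any trend across chain length and branching remains tentative.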